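Replacing Methyl with Hydrogen at the Assay's Limit

The source may hold more compounds than are shown below. What is called first, only, known or untested is meant among the compounds shown, and "the series" means these compounds.

Compound 1 `FC(F)(F)c1ccc(NCc2cn(-c3ccccc3)nc2-c2ccc(Br)cc2)cc1`: 28000 nM
Compound 2 `Brc1ccc(NCc2cn(-c3ccccc3)nc2-c2ccc(Br)cc2)cc1`: 88000 nM
Compound 3 `Cc1ccc(NCc2cn(-c3ccccc3)nc2-c2ccc(Br)cc2)cc1`: > 100000 nM (a limit)

All three values come from an ADME assay on Vero 76 cells (Chlorocebus sabaeus) for cytotoxicity, read by MTT assay, with a stated time of 96 h; on this read-out lower numbers stand for higher toxicity in this test and higher numbers for lower toxicity in this test. Compound 3 gives > 100000 nM, which is a limit of the assay and not a number.

Compound 4 `Brc1ccc(-c2nn(-c3ccccc3)cc2CNc2ccccc2)cc1` differs from compound 3 by a single change, hydrogen in place of methyl on an aromatic carbon.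

Within the data shown here, no measured step makes this exact swap, but three steps change the same place on the same ring. Two of them start from the trifluoromethyl group of compound 1, and both are modest: a 3.1-fold higher number from compound 1 to compound 2 (0.50 log units; beyond the scatter) and an at least 3.5-fold higher number from compound 1 to compound 3 (0.55 log units; beyond the scatter). The third is an at least 1.1-fold higher number from compound 2 to compound 3 (0.05 log units; that floor lies within the scatter), and its floor lies within the scatter, so it shows no clear change. The step to compound 4 involves no trifluoromethyl group, which makes the step from compound 2 the closer guide.

No change beyond the scatter is therefore expected in this assay, and the assay may again report only a limit. The expected step is a number no higher from compound 3 to compound 4 (the limit leaves the size open). For compound 4 the estimate is 100000 nM, with an expected range from 50000 nM to 150000 nM.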

Compound 4, half-maximal cytotoxic concentration: 52000 nM
Estimate against measurement, compound 4: 1.9-fold (0.28 log units) above; the range from low to high includes it.
By their numbers in this assay, from the lowest: compounds 1, 4 and 2 (each within the scatter of the next, the first and the last beyond it). At a limit, above all of these: compound 3.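

In this assay compound 3 gives > 100000 nM, which is a limit and not a number. Removing the methyl gives a measured value for the plain anilino compound, but the step, an at least 1.9-fold lower number from compound 3 to compound 4 (0.28 log units; that floor lies within the scatter), does not show a clear change. Compound 4 also lies within the scatter of the other two measured compounds, with a 1.7-fold lower number from compound 2 to compound 4 (0.23 log units; within the scatter) and a 1.9-fold higher number from compound 1 to compound 4 (0.27 log units; within the scatter), even though those two differ from each other by more than the scatter, so hydrogen at this position fits between bromo and trifluoromethyl without standing clearly apart from either.

Among these compounds, the true distance between compound 3 and the other compounds remains unknown, as does the full size of the step from methyl to hydrogen, and the only information at that end of the scale is this: the limit of > 100000 nM in this assay, at which 1 of the 4 values shown sits. It also remains open whether a different kind of group on this aromatic carbon, such as an amine, a carboxylic acid or a longer chain, would move the number beyond the scatter, and in which direction.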